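The source may report more compounds than this note shows. Statements on the series, on what has been measured and on what is new or still open speak of the compounds shown alone.

Compound 1 (`CC(=O)N[C@H](C(=O)N1C[C@H](O)C[C@H]1C(=O)N[C@@H](CCC(C)(C)C)c1ccc(-c2scnc2C)cc1)C(C)(C)C`): (3.21)
Compound 2 (`CC(=O)N[C@H](C(=O)N1C[C@H](O)C[C@H]1C(=O)N[C@@H](CCC(=O)O)c1ccc(-c2scnc2C)cc1)C(C)(C)C`): (1.02)

In a physicochemical assay for lipophilicity, measured as octanol-water partition (a higher number here means a more lipophilic compound, a lower number a more polar compound), compound 2 stands lowest of the two measured compounds at 1.02 on this scale. Compound 3 (`CC(=O)N[C@H](C(=O)N1C[C@H](O)C[C@H]1C(=O)N[C@@H](CCc1ccc(O)cc1)c1ccc(-c2scnc2C)cc1)C(C)(C)C`) differs from compound 2 by a single change (4-hydroxyphenyl in place of carboxy on a saturated chain carbon, three bonds along the chain from an amide-type nitrogen and an aromatic carbon) in the chain. Among the measured compounds shown here, only one measured step bears on this: carboxy in place of tert-butyl gave a number 2.19 log units lower from compound 1 to compound 2 (beyond the scatter) as a large step, and since carboxy now leaves, a large rise is expected, although 4-hydroxyphenyl is not tert-butyl and the rise may fall somewhat short of that step. The expected step is a number 1.78 log units higher from compound 2 to compound 3 (beyond the scatter) on this estimate. For compound 3 the estimated value is 2.8 (expected range 2.2 to 3.4).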

Compound 3, partition coefficient: 3.08
The estimate for compound 3 lay 0.28 log units below the measured number; low and high end bracket the measured number.
By their numbers in this assay, from the lowest: compound 2; then compounds 3 and 1 (each within the scatter of the next).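

In this assay, 4-hydroxyphenyl in place of carboxy on this chain carbon gives a number 2.06 log units higher from compound 2 to compound 3 (beyond the scatter), so the large step seen earlier is not tied to tert-butyl alone. In place of tert-butyl, the same group gives a number 0.13 log units lower from compound 1 to compound 3 (within the scatter), so this read-out does not separate these two groups, and of the three compounds only the carboxy compound stands apart. No evidence at hand accounts for these numbers. Going by these compounds, what an amine or an unsubstituted phenyl would give at this place stays open, as does the effect of a longer chain.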